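This account rests on a few compounds, and the source may have more. Where it says the series, first, only, none or still open, it means among the compounds named here.

Compound 1 `O=C1/C(=C/c2ccccc2)NS(=O)(=O)c2ccccc21` sits at the lower end of the numbers in hand: in an assay for inhibition of alkaline phosphatase, tissue-nonspecific isozyme (Homo sapiens), read by spectrophotometry, with stated times of 10 min and 20 min (on this read-out lower numbers stand for stronger inhibition and higher numbers for weaker inhibition), compound 1 gives 660 nM. Its nearest neighbour is compound 3 `O=C1/C(=C/c2ccc(F)cc2)NS(=O)(=O)c2ccccc21`, which in this assay gives 1350 nM, a step of a 2.0-fold higher number from compound 1 to compound 3 (0.31 log units; beyond the scatter). Compound 2 `COc1cccc(/C=C2\NS(=O)(=O)c3ccccc3C2=O)c1` gives only a limit in this assay, > 200000 nM. The corresponding step, an at least 300-fold higher number from compound 1 to compound 2 (2.48 log units; beyond the scatter), is therefore known only as a floor, as the limit of > 200000 nM in this assay, at which 1 of the 3 values shown sits, records.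

Compound 4 `O=C1/C(=C/c2cccc(O)c2)NS(=O)(=O)c2ccccc21` differs from compound 1 by hydroxy in place of hydrogen on an aromatic carbon. Of the two measured steps, the methoxy step from compound 1 to compound 2 bears most directly on it, since it too places an oxygen-bearing group on the aromatic carbon meta to a large group, and it was large; the fluoro step was modest. A hydroxy is not a methoxy, so compound 4 is expected to lose potency against compound 1, but not necessarily to the floor. Compound 4 is thus estimated at 10000 nM, with a range of 2000 nM to 100000 nM, an expected step of a 15-fold higher number from compound 1 to compound 4 (1.18 log units; beyond the scatter).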

Compound 4, half-maximal inhibitory concentration: 3570 nM
Compound 4: middle estimate off by 2.8-fold (0.45 log units), on the high side; low and high end bracket the measured number.
By their numbers in this assay, from the lowest: compound 1; then compound 3; then compound 4. At a limit, above all of these: compound 2.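

In this assay, placing an oxygen on this aromatic carbon, meta to a large group, does not by itself bring the large loss seen with methoxy: hydroxy in place of hydrogen gives a 5.4-fold higher number from compound 1 to compound 4 (0.73 log units; beyond the scatter), while taking the methyl off the oxygen gives an at least 56-fold lower number from compound 2 to compound 4 (1.74 log units; beyond the scatter). Much of that loss therefore goes with the methyl on the oxygen, although the size of this step is only a floor, as compound 2 gives a limit and not a number: the limit of > 200000 nM in this assay, at which 1 of the 4 values shown sits. Compound 4 also lies at a 2.6-fold higher number from compound 3 to compound 4 (0.42 log units; beyond the scatter), but that pair differs in both the group and its place, so it says little about this position alone.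

As far as these compounds go, whether an amine or a carboxylic acid on this carbon would match or better hydrogen remains open. So does whether a longer chain on the oxygen would behave as the methyl does.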